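This account rests on a few compounds, and the source may have more. Where it says the series, first, only, none or still open, it means among the compounds named here.

Measured compounds in a functional assay on A375P cells (Homo sapiens) for antiproliferative activity, read by MTT assay, with a stated time of 48 h; a higher number here means a weaker inhibitor, a lower number a stronger inhibitor:
compound 1, `Nc1cccc2c(-c3cccc(NC(=O)c4ccc(Cl)c(C(F)(F)F)c4)c3)ccnc12`: 1400 nM
compound 2, `Nc1cccc2c(-c3cccc(NC(=O)c4ccc5c(c4)OCCO5)c3)ccnc12`: 860 nM
compound 3, `Cc1ccc(NC(=O)c2ccc(Cl)c(C(F)(F)F)c2)cc1-c1ccnc2c(N)cccc12`: 3300 nM

The three measured compounds share a common core and differ in the amide-bearing part and in one further substitution. Compound 1 and compound 2 carry different amide groups, and the difference between these two cores is not broken down here; in this assay compound 1 gives 1400 nM and compound 2 gives 860 nM, two values that lie within the scatter of each other, so no order between them is claimed. Compound 3 is compound 1 with one change, (methyl in place of hydrogen on an aromatic carbon), and this brought a 2.4-fold higher number from compound 1 to compound 3 (0.37 log units; beyond the scatter).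

Compound 4, `Cc1ccc(NC(=O)c2ccc3c(c2)OCCO3)cc1-c1ccnc2c(N)cccc12`, is not yet measured. It stands to compound 2 as compound 3 stands to compound 1: the change is methyl in place of hydrogen on an aromatic carbon, and the place is described in the same words in both cases, so it is the same change on a different core. Among the compounds with values here, the one measured instance of this change rests on a single pair, compound 1 and compound 3, and the account expects a step of similar size, a 2.3-fold higher number from compound 2 to compound 4 (0.37 log units; beyond the scatter), because the earlier step was a 2.4-fold higher number from compound 1 to compound 3 (0.37 log units; beyond the scatter). On that basis compound 4 is estimated in this assay at 2000 nM, with a range from 900 nM to 5000 nM.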

Compound 4, half-maximal inhibitory concentration: 280 nM
Beside the measured number, compound 4's estimate is 7.1-fold (0.85 log units) above it; the measured number lies below the stated range.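

In this assay, within the data shown here, methyl in place of hydrogen on an aromatic carbon brought a 3.1-fold lower number from compound 2 to compound 4 (0.49 log units; beyond the scatter) and so ran the opposite way to the one earlier instance of the same change, which shows that the step did not carry over from the core of compound 1 to the core of compound 2: the same change on two cores in this assay, a 2.4-fold higher number (0.37 log units; beyond the scatter) from compound 1 to compound 3 and a 3.1-fold lower number (0.49 log units; beyond the scatter) from compound 2 to compound 4, 7.2-fold (0.86 log units) apart, beyond the scatter of two such steps.

Within this series, then, the sign of the step went with the amide group that the shared core carries, and a step read on one amide group gave no safe guide to the step on the other. Among these compounds, the result rests on only two pairs, however, so it does not show how the methyl would act with any third amide group, nor does it show why the two steps part.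

The compounds shown leave open whether other amide groups would follow compound 3 or compound 4 when this methyl enters. They also leave open whether a group other than methyl, such as an ethyl, a methoxy or a fluorine, on the same aromatic carbon, ortho to a large group and para to a large group, would split the two cores in the same way.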